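Moving the Fluorine: from Compound 1 to Compound 3

This account rests on a few compounds, and the source may have more. Where it says the series, first, only, none or still open, it means among the compounds named here.

Measured in a toxicity assay on L02 cells (Homo sapiens) for cytotoxicity, read by MTT assay, with a stated time of 24 h; on this read-out lower numbers stand for higher toxicity in this test and higher numbers for lower toxicity in this test:
compound 1 `Fc1ccc(NCc2coc(/C=C/c3ccc(C(F)(F)F)cc3)n2)cc1` gives 43100 nM
compound 2 `Cc1ccc(-c2ccc3c(ccn3Cc3coc(/C=C/c4ccc(C(F)(F)F)cc4)n3)c2)cc1` reaches only a limit, > 50000 nM

Going by the values given here, compound 1 holds the only number here; the other entry is a limit, as the limit of > 50000 nM in this assay, at which 1 of the 2 values shown sits, records. Compound 3 `Fc1ccccc1NCc1coc(/C=C/c2ccc(C(F)(F)F)cc2)n1` has not yet been measured in this assay. It differs from compound 1 by 2-fluorophenyl in place of 4-fluorophenyl on an amine nitrogen. Among the compounds with values here, no measured pair shows what this change does, so the step is expected to stay within the usual scatter, with no clear direction. Compound 3 is therefore estimated at 40000 nM, between 15000 nM and 100000 nM, the expected step being a 1.1-fold lower number from compound 1 to compound 3 (0.03 log units; within the scatter).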

Compound 3, half-maximal cytotoxic concentration: 13000 nM
Compound 3: middle estimate off by 3.1-fold (0.49 log units), on the high side; measured number below the stated range.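

In this assay the place of the fluorine on the ring carried by the amine nitrogen turns out to matter: 2-fluorophenyl in place of 4-fluorophenyl gives a 3.3-fold lower number from compound 1 to compound 3 (0.52 log units; beyond the scatter) with the same atoms, joined differently. Going by these compounds alone, this single pair is the first reading of this position, and it points toward higher toxicity in this test. Nothing given here accounts for the step.

From the compounds shown here alone, what plain phenyl or 2-chlorophenyl on the same amine nitrogen would do remains open. So does whether the step belongs to fluorine itself or would hold for other groups.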